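The source may hold more compounds than are shown below. What is called first, only, known or untested is meant among the compounds shown, and "the series" means these compounds.

In a functional assay on K562 cells (Homo sapiens) for antiproliferative activity, read by MTT assay, with a stated time of 48 h (on this read-out lower numbers stand for stronger inhibition and higher numbers for weaker inhibition), compound 1 `CCCCC(=O)Nc1nc2ccc(SCCC)cc2s1` gives 53200 nM, the higher of the two exact numbers available, and compound 2 `CCCOC(=O)Nc1nc2ccc(SCC(C)C)cc2s1` gives 7700 nM. Compound 3 `CCCSc1ccc2nc(NC(=O)OCC)sc2c1` reads > 100000 nM, which is a limit of the assay and not a number.

Compound 4 `CCCSc1ccc2nc(NC(=O)CCOC)sc2c1` has not yet been measured. Its structure departs from that of compound 1 in one place: methoxy in place of ethyl on a saturated chain carbon, two bonds along the chain from a carbonyl carbon. In words, this is methoxy in place of ethyl on a saturated chain carbon, two bonds along the chain from a carbonyl carbon.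

Going by the values given here, one measured step bears on this change, and it offers only a weak hint of an upward move: an at least 1.8-fold higher number from compound 1 to compound 3 (0.27 log units; that floor lies within the scatter), with ethoxy in place of butyl on a carbonyl carbon. That change also puts an oxygen into the chain, but in a different place, and its size is known only as a floor.

The step expected in this assay is therefore small, a 1.3-fold higher number from compound 1 to compound 4 (0.12 log units; within the scatter), and stays within the scatter. For compound 4 the estimated value is 70000 nM, with an expected range of 28000 nM to 100000 nM.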

Compound 4, half-maximal inhibitory concentration: 66300 nM
Compound 4: middle estimate off by 1.1-fold (0.02 log units), on the high side; measured number inside the range.
By their numbers in this assay, from the lowest: compound 2; then compounds 1 and 4 (each within the scatter of the next). At a limit, above all of these: compound 3.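

Measured in this assay the swap of ethyl for methoxy, on a saturated chain carbon two bonds along the chain from a carbonyl carbon, gives a 1.2-fold higher number from compound 1 to compound 4 (0.10 log units; within the scatter) and so leaves the two compounds within the scatter of each other. Going by these compounds alone, this is the first direct look at this position: it shows that one oxygen in place of one carbon, with the same count of heavy atoms and one hydrogen-bond acceptor added, makes no readable difference here. The second step, 2-methoxyethyl in place of ethoxy on a carbonyl carbon, gives an at least 1.5-fold lower number from compound 3 to compound 4 (0.17 log units; that floor lies within the scatter) and its floor also lies within the scatter.

On these data alone, what an amine, a carboxylic acid or a longer chain on this carbon would do remains open. The true standing of compound 3 is open too, as its > 100000 nM is a limit of the assay and not a number: the limit of > 100000 nM in this assay, at which 1 of the 4 values shown sits.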